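This account rests on a few compounds, and the source may have more. Where it says the series, first, only, none or still open, it means among the compounds named here.

In a functional assay on SK-MEL-28 cells (Homo sapiens) for inhibition, read by MTT assay, with a stated time of 48 h (a higher number here means a weaker inhibitor, a lower number a stronger inhibitor), three compounds built on one shared core have been tested so far. Compound 1 `CS(=O)(=O)c1ccc(-c2nc3ccccn3c2Sc2ccccc2)cc1`, which carries methylsulfonyl, gives 61900 nM. Compound 2 `CCc1ccc(-c2nc3ccccn3c2Sc2ccccc2)cc1`, with ethyl in that place, gives > 100000 nM, which is a limit of the assay and not a number. Compound 3 `Cc1ccc(-c2nc3ccccn3c2Sc2ccccc2)cc1`, with methyl there, gives > 100000 nM, which is also a limit. Compound 3 therefore has no exact value to build on.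

The next structure, compound 4 `COc1ccc(-c2nc3ccccn3c2Sc2ccccc2)cc1`, has methoxy in place of methyl on an aromatic carbon, para to a large group: methoxy in place of methyl on an aromatic carbon.

For the measured compounds named here, no measured step makes this exact change, but three involve the same substituent. Replacing methylsulfonyl gave an at least 1.6-fold higher number from compound 1 to compound 2 (0.20 log units; that floor lies within the scatter) and an at least 1.6-fold higher number from compound 1 to compound 3 (0.20 log units; that floor lies within the scatter). Exchanging the two small groups gave a step that the two limits leave unreadable from compound 2 to compound 3. None of these steps therefore shows a change beyond the scatter, so this assay offers no reason to expect a clear shift in either direction for methoxy. The expected change is no larger than the scatter, and the estimated step is an at least 1.1-fold lower number from compound 3 to compound 4 (0.04 log units; that floor lies within the scatter). The result may well be another limit rather than a number. For compound 4, the estimated value is 90000 nM, with an expected range from 40000 nM to 200000 nM.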

Compound 4, half-maximal inhibitory concentration: 83900 nM
Compound 4: the middle estimate sits 1.1-fold (0.03 log units) above what was measured; the measured number falls inside the stated range.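

In this assay methoxy, on this aromatic carbon para to a large group, gives a readable number where methyl and ethyl gave only limits, so compound 4 joins compound 1 as the second compound here with an exact value. The change to methoxy gives an at least 1.1-fold lower number from compound 3 to compound 4 (0.07 log units; that floor lies within the scatter) and an at least 1.1-fold lower number from compound 2 to compound 4 (0.07 log units; that floor lies within the scatter); both are only floors that lie within the scatter, because each starts from a compound sitting at a limit: the limit of > 100000 nM in this assay, at which 2 of the 4 values shown sit. The one step between two exact values is a 1.4-fold higher number from compound 1 to compound 4 (0.13 log units; within the scatter), so methoxy and methylsulfonyl cannot be told apart in this assay, and no step shown so far lies beyond the scatter.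

The compounds shown leave open what an amine, a carboxylic acid or a longer chain such as butyl would do at this place, and whether any group there can produce a step beyond the scatter. On these data alone, it also remains open whether a change elsewhere on the shared core would move the number more than these exchanges on the 4-substituted phenyl group have done.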